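Adding a methyl to the methoxy group of compound 2

The source may report more compounds than this note shows. Statements on the series, on what has been measured and on what is new or still open speak of the compounds shown alone.

Among the measured compounds shown here, in an ADME assay on the whole organism (plasma, strain CD1) for pharmacokinetics, with Mus musculus as the target, at a dose of 30 mg/kg by the oral route (a higher number here means more compound in the circulation at the dose given, a lower number less compound in the circulation), compound 2 `CCOC(=O)c1c(-c2cccc(OC)c2)[nH]c2cc(OC)ccc2c1=O` gives 2830 ng.h/mL as the higher of the two numbers so far, while compound 1 `CCOC(=O)c1c(-c2cccc(-c3ccccc3)c2)[nH]c2cc(OC)ccc2c1=O` gives 679 ng.h/mL after the same oral dose. The next candidate, compound 3 `CCOC(=O)c1c(-c2cccc(OCC)c2)[nH]c2cc(OC)ccc2c1=O`, keeps the shared core and differs from compound 2 in one small way. The change is methyl in place of hydrogen on a saturated chain carbon bound to an oxygen on an aromatic ring and it turns methoxy into ethoxy, or 3-methoxyphenyl into 3-ethoxyphenyl.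

For the measured compounds named here, only one measured step bears on this: a 4.2-fold higher number from compound 1 to compound 2 (0.62 log units; beyond the scatter) with methoxy in place of phenyl on an aromatic carbon, a modest rise that lies beyond the scatter. Adding a methyl is a much smaller edit than that swap, so in this assay only a slight drop toward compound 1 at 679 ng.h/mL is expected, and none beyond the scatter. With just two measured compounds, this expectation rests on thin evidence. The estimated step is a 1.2-fold lower number from compound 2 to compound 3 (0.07 log units; within the scatter) and it could fall either way. Compound 3 is expected at 2400 ng.h/mL with an estimated range from 1000 ng.h/mL to 5500 ng.h/mL in this measurement.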

Compound 3, area under the concentration-time curve: 1870 ng.h/mL
For compound 3 the middle estimate is 1.3-fold (0.11 log units) above the measured one, and the stated range covers the measured number.
By their numbers in this assay, from the lowest: compound 1; then compounds 3 and 2 (each within the scatter of the next).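

In this assay, going from methoxy to ethoxy on the aromatic ring gives a 1.5-fold lower number from compound 2 to compound 3 (0.18 log units; within the scatter), so the extra methyl on the saturated chain carbon leaves compound 2 and compound 3 impossible to tell apart. The earlier pair showed only that methoxy in place of phenyl separates two compounds, while ethoxy in place of phenyl now gives a 2.8-fold higher number from compound 1 to compound 3 (0.44 log units; beyond the scatter), which is also beyond the scatter. Among these three compounds, then, the one carrying phenyl stands apart from both compounds carrying a short chain on the oxygen, and neither compound 2 nor compound 3 goes against this. Nothing available here explains why these numbers fall as they do.

From the compounds shown here alone, what remains open is how far this tolerance for a slightly larger group extends: a longer chain such as propoxy or butoxy, or a branched one such as isopropoxy, could stay level with compound 3 or drop toward compound 1. A hydroxyl group or an amine in the same place could also behave quite differently from either of these short chains on the oxygen.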